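The compounds below may be only part of what the source reports. "The series", "measured", "known", "first", "only" and "open" are said of these compounds alone.

Measured in a functional assay on NCI/ADR-RES cells (Homo sapiens) for antiproliferative activity; on this read-out lower numbers stand for stronger inhibition of growth and higher numbers for weaker inhibition of growth:
- compound 1 `CC/C=C\[C@H](C)[C@H](OC(N)=O)[C@@H](C)[C@H](O)[C@@H](C)C/C(C)=C\[C@H](C)[C@@H](O)[C@@H](C)/C=C\[C@@H](O)C[C@@H]1OC(=O)[C@H](C)C[C@H]1C` gives 140 nM
- compound 2 `CC/C=C\[C@H](C)[C@H](OC(N)=O)[C@@H](C)[C@H](O)[C@@H](C)C/C(C)=C\[C@H](C)[C@@H](O)[C@@H](C)/C=C\[C@@H](O)C[C@@H]1OC(=O)NC[C@H]1C` gives 10000 nM
- compound 3 `CC/C=C\[C@H](C)[C@H](OC(N)=O)[C@@H](C)[C@H](O)[C@@H](C)C/C(C)=C\[C@H](C)[C@@H](O)[C@@H](C)/C=C\[C@@H](O)C[C@@H]1OC(=O)[C@H](C)[C@@H](OC)[C@H]1C` gives 250 nM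

Compound 3 cannot be separated from compound 1 on these numbers (a 1.8-fold higher number from compound 1 to compound 3 (0.25 log units; within the scatter)). Compound 2 lies far off (a 40-fold lower number from compound 2 to compound 3 (1.60 log units; beyond the scatter)).

The next entry is compound 4 `CC/C=C\[C@H](C)[C@H](OC(N)=O)[C@@H](C)[C@H](O)[C@@H](C)C/C(C)=C\[C@H](C)[C@@H](O)[C@@H](C)/C=C\[C@@H](O)C[C@@H]1OC(=O)[C@H](C)[C@@H](O)[C@H]1C`, not yet measured. The change is hydrogen in place of methyl on an oxygen on a saturated carbon (hydrogen in place of methyl on an oxygen on a saturated carbon; the same difference reads methoxy to hydroxy).

The closest evidence is the step that introduced the methoxy group, methoxy in place of hydrogen on a saturated ring carbon (a 1.8-fold higher number from compound 1 to compound 3 (0.25 log units; within the scatter)). That step stayed within the scatter. The large step to compound 2 (a 71-fold higher number from compound 1 to compound 2 (1.85 log units; beyond the scatter)) is a different group exchange and bears on this change only weakly. Among the compounds with values here, no measured compound carries the free hydroxy, so the expectation rests on that one small step.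

In this assay the estimated step is small and none beyond the scatter is expected (a 1.5-fold lower number from compound 3 to compound 4 (0.17 log units; within the scatter)). The estimate sits close to the values of the two neighbouring compounds, with a wide range.

The expected value for compound 4 is 170 nM (estimated range 60 nM to 500 nM).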

Compound 4, concentration for 50% growth inhibition: 190 nM
Compound 4: the middle estimate sits 1.1-fold (0.05 log units) below what was measured; measured number inside the range.
By their numbers in this assay, from the lowest: compounds 1, 4 and 3 (each within the scatter of the next); then compound 2.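

In this assay, the step from methoxy to hydroxy gives a 1.3-fold lower number from compound 3 to compound 4 (0.12 log units; within the scatter), and hydroxy in place of hydrogen on the saturated ring carbon gives a 1.4-fold higher number from compound 1 to compound 4 (0.13 log units; within the scatter), so hydrogen, methoxy and hydroxy at this position cannot be told apart on these numbers. Within the data shown here, the free hydroxy adds a third substituent state to the one small step available earlier, and the methyl on the oxygen shows no readable contribution to the read-out. The large gap to the carbamate-type ring of compound 2 also remains with the free hydroxy present, at a 53-fold lower number from compound 2 to compound 4 (1.72 log units; beyond the scatter), while no measured evidence bears on why this position is so insensitive.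

As far as these compounds go, whether the flat response at this position extends to an amine, a carboxylic acid or a longer alkoxy chain remains open. Also open, from the compounds shown here alone, is which part of the group exchange in compound 2 carries the large step, since that exchange alters more than one feature of the ring at once.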